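The source may report more compounds than this note shows. Statements on the series, on what has been measured and on what is new or still open speak of the compounds shown alone.

Measured compounds:
compound 1 `c1ccc(CN2CCC3(CC2)OCCc2c3csc2-c2ccccc2)cc1`: 4.5 nM
compound 2 `COc1ccc(-c2scc3c2CCOC32CCN(Cc3ccccc3)CC2)cc1`: 1.5 nM
compound 3 `COC1Cc2cc(-c3ccccc3)sc2C2(CCN(Cc3ccccc3)CC2)O1`: 16 nM

All three were run in an assay on membranes from brain for displacement of a labelled ligand from Sigma non-opioid intracellular receptor 1 (Cavia porcellus), read by scintillation counting, with a stated time of 120 min; a higher number here means a weaker inhibitor, a lower number a stronger inhibitor. Compound 3 carries the highest number of the three, and the gaps to compound 1 and to compound 2 lie beyond the scatter. The difference between the core of compound 1 and the core of compound 3 is not broken down here. Between compound 1 and compound 2 the change is methoxy in place of hydrogen on an aromatic carbon, and it gave a 3.0-fold lower number from compound 1 to compound 2 (0.48 log units; beyond the scatter).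

Compound 4 `COc1ccc(-c2cc3c(s2)C2(CCN(Cc4ccccc4)CC2)OC(OC)C3)cc1` has not yet been measured in this assay. It differs from compound 3 by methoxy in place of hydrogen on an aromatic carbon. The place is described in the same words as for the change from compound 1 to compound 2, so this is the same change applied to the core of compound 3. The expected step in this assay is a 2.7-fold lower number from compound 3 to compound 4 (0.43 log units; beyond the scatter), resting on the step from compound 1 to compound 2 of a 3.0-fold lower number from compound 1 to compound 2 (0.48 log units; beyond the scatter); a step of about the same size is expected here, with the usual scatter allowed for. Compound 4 is therefore estimated at 6 nM, between 2.5 nM and 15 nM.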

Compound 4, inhibition constant: 56 nM
The estimate for compound 4 lay 9.3-fold (0.97 log units) below the measured number, and the stated range ends below it.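

In this assay, the change from phenyl to 4-methoxyphenyl gave a 3.5-fold higher number from compound 3 to compound 4 (0.54 log units; beyond the scatter). Carried from one core to the other, the same change reversed direction, and the two steps clearly differ: the same change on two cores in this assay, a 3.0-fold lower number (0.48 log units; beyond the scatter) from compound 1 to compound 2 and a 3.5-fold higher number (0.54 log units; beyond the scatter) from compound 3 to compound 4, 11-fold (1.02 log units) apart, beyond the scatter of two such steps The step seen on the core of compound 1 therefore cannot be assumed to hold on the core of compound 3, but with only one matched pair on each core, these data do not show which difference between the cores goes with the reversal, or how the change behaves on any further core.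

Still open, on these data alone, is whether the reversal is particular to methoxy or also appears with other groups in the same place, such as chloro or hydroxyl, on both cores. Also open, as far as these compounds go, is whether the two cores still part in this way when the benzyl group on the ring nitrogen gives way to a longer chain, such as phenethyl.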